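The source may report more compounds than this note shows. Statements on the series, on what has been measured and on what is new or still open speak of the compounds shown alone.

Measured compounds in an assay on isolated protein for inhibition of DNA topoisomerase 1 (Homo sapiens), with a stated time of 30 min, tested at 20 uM; on this read-out lower numbers stand for a weaker effect and higher numbers for a stronger effect at the one concentration tested:
- compound 1 `Oc1ccc(-c2cc(-c3cccs3)cc(-c3ccccc3O)n2)cc1`: 2%
- compound 2 `Oc1ccccc1-c1cc(-c2ccsc2)cc(-c2ccccc2O)n1`: "not determined" (no result reported), no number reported
- compound 3 `Oc1ccccc1-c1cc(-c2ccco2)cc(-c2ccccc2O)n1`: 0.2%

In this assay compound 3 gives 0.2%, the lower of the two numbers in hand. The nearest entry is compound 1 at 2%, and the two lie within the scatter of each other, so no order between them can be read. Compound 2 contributes no number. The next compound, compound 4 `Oc1ccc(-c2cc(-c3ccco3)cc(-c3ccccc3O)n2)cc1`, differs from compound 3 in one place: 4-hydroxyphenyl in place of 2-hydroxyphenyl on an aromatic carbon The two have the same atoms, joined differently.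

Within the data shown here, no pair of measured compounds stands on either side of a single change, so no step size is known for this series. Among the measured compounds shown here, the only guide is that both numbers in hand are small and indistinguishable; compound 4 is expected to stay in the same region because compound 1 with a 4-hydroxyphenyl gives 2%. The step of a number 1.3 percentage points higher from compound 3 to compound 4 (within the scatter) is therefore expected to be none beyond the scatter, in either direction. Compound 4 is estimated at 1.5%, with an expected range from 0% to 8%.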

Compound 4, a percentage reported as inhibition, at one concentration (the size of the read-out at that concentration, not a potency): 0%
Beside the measured number, compound 4's estimate is 1.5 percentage points above it; measured number inside the range.
By their numbers in this assay, from the lowest: compounds 4, 3 and 1 (each within the scatter of the next).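

In this assay, among these compounds, 4-hydroxyphenyl in place of 2-hydroxyphenyl on the aromatic carbon next to the ring nitrogen gives a number 0.2 percentage points lower from compound 3 to compound 4 (within the scatter) and is the first single change read at this position; in this furan-2-yl series, the two hydroxyphenyl groups cannot be told apart in this read-out. Furan-2-yl in place of thiophen-2-yl gives a number 2 percentage points lower from compound 1 to compound 4 (within the scatter), so the exchange of these two rings, with 4-hydroxyphenyl and 2-hydroxyphenyl both retained, also produces no readable separation at the one concentration tested. No measurement is available that bears on these results, and neither step can be tied to an explanation.

On these data alone, what remains open is whether any replacement at this position can separate from compounds 1, 3 and 4, since the two steps read so far explore only hydroxyphenyl isomers and two five-membered rings. A methoxy group in place of the hydroxyl, or an amine or a carboxylic acid on the phenyl ring, would test whether the read-out responds to a change of group rather than a change of attachment.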